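The compounds below may be only part of what the source reports. "The series", "measured", "known", "first", "only" and "open" are said of these compounds alone.

Compound 1 `COc1ccc(-c2cc3ccccc3nc2C=O)cc1` carries a formyl group on its shared core. In a functional assay on MCF7 cells (Homo sapiens) for antiproliferative activity, read by XTT assay, with a stated time of 72 h (a lower number here means a stronger inhibitor, a higher number a weaker inhibitor), compound 1 stands at the limit of > 10000 nM in this assay, at which 1 of the 3 values shown sits, a limit of the assay rather than a number, recorded as > 10000 nM. Two measured relatives replace that formyl with a longer chain ending in a carbonyl attached to a ring. Compound 2 `COc1ccc(C(=O)/C=C/c2nc3ccccc3cc2-c2ccc(OC)cc2)cc1` gives 7380 nM in this assay, and compound 3 `COc1ccc(-c2cc3ccccc3nc2/C=C/C(=O)c2ccsc2)cc1` gives 6010 nM. The step of an at least 1.6-fold lower number from compound 1 to compound 3 (0.22 log units; that floor lies within the scatter) shows that the longer chain with a thiophen-3-yl carbonyl lowers the number from the limit, while the step of a 1.2-fold lower number from compound 2 to compound 3 (0.09 log units; within the scatter) shows that exchanging 4-methoxyphenyl for thiophen-3-yl on the carbonyl carbon changes little. Compound 4 `COc1ccc(-c2cc3ccccc3nc2/C=C/C(=O)c2ccc[nH]2)cc1` is not yet measured; it differs from compound 1 by 2-((1H-pyrrol-2-yl)carbonyl)ethenyl in place of formyl on an aromatic carbon. Both measured steps bear on it: the first gives the size of going from formyl to the longer chain, and the second suggests that the ring on the carbonyl carbon matters less than the chain itself. Compound 4 is therefore expected to come in under the limit seen for its parent, a step estimated at an at least 1.8-fold lower number from compound 1 to compound 4 (0.25 log units; that floor lies within the scatter). The estimate for compound 4 is 5500 nM, with a range of 2500 nM to 12000 nM.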

Compound 4, half-maximal inhibitory concentration: > 10000 nM
Compound 4 was reported as a limit; the forecaster's own chance of this, stated with the estimate: 15%; middle value at least 1.8-fold (0.25 log units) away from the limit.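

Compound 4 sits at a limit of the assay rather than at a number, as compound 1 does, so the step between them cannot be read: the limit of > 10000 nM in this assay, at which 2 of the 4 values shown sit. With the chain kept and only the ring on the carbonyl carbon exchanged, this assay shows an at least 1.6-fold higher number from compound 3 to compound 4 (0.22 log units; that floor lies within the scatter) and an at least 1.3-fold higher number from compound 2 to compound 4 (0.13 log units; that floor lies within the scatter), so the real gaps may be small or may be larger than these floors. Even so, the longer chain does not by itself bring a compound under the limit, and the ring at its end may count for more than the within-scatter pair of compound 2 and compound 3 suggested.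

As far as these compounds go, how far compound 4 lies past the limit remains unknown, so the size of this ring exchange stays open. The compounds shown also include no 1-methyl-1H-pyrrol-2-yl or furan-2-yl on the carbonyl carbon, so they cannot tell whether the hydrogen on the ring nitrogen of compound 4 plays any part.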